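Working notes: from compound 2 to compound 3

The source may hold more compounds than are shown below. What is called first, only, known or untested is meant among the compounds shown, and "the series" means these compounds.

- compound 1 `COc1ccc(Nc2nc3c(c(Oc4cccc(NC(=O)/C=C/C(C)C)c4)n2)CSCC3)cc1` gives 25900 nM in the first test below
- compound 2 `CC/C=C/C(=O)Nc1cccc(Oc2nc(Nc3ccc(OC)nc3)nc3c2CSCC3)c1` gives 13100 nM in the same test

In a functional assay on A549 cells (Homo sapiens) for antiproliferative activity, read by MTT assay, with a stated time of 72 h (on this read-out lower numbers stand for stronger inhibition and higher numbers for weaker inhibition), compound 2 stands at 13100 nM and compound 1 at 25900 nM, so the two lie within the usual scatter of each other and neither can be ranked over the other.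

Compound 3 `COc1ccc(Nc2nc3c(c(Oc4cccc(NC(=O)/C=C/C(C)C)c4)n2)CSCC3)cn1` follows from compound 2 by one change (methyl in place of hydrogen on a saturated chain carbon bound to a double-bonded chain carbon and a saturated chain carbon): methyl in place of hydrogen on a saturated chain carbon bound to a double-bonded chain carbon and a saturated chain carbon. This turns but-1-en-1-yl into 3-methylbut-1-en-1-yl.

Among the measured compounds shown here, no pair of measured compounds differing in one place exists yet, so the series offers no direct precedent for this change. For the measured compounds named here, the only guide in this assay is the narrow span set by compound 1 at 25900 nM and compound 2 at 13100 nM. No step beyond the scatter is expected, and no direction can be claimed firmly. An estimated 1.3-fold higher number from compound 2 to compound 3 (0.11 log units; within the scatter) stays within the scatter. For compound 3 the estimate is 17000 nM (expected range 8000 nM to 36000 nM).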

Compound 3, half-maximal inhibitory concentration: 24200 nM
The estimate for compound 3 lay 1.4-fold (0.15 log units) below the measured number; low and high end bracket the measured number.
By their numbers in this assay, from the lowest: compounds 2, 3 and 1 (each within the scatter of the next).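

In this assay, among the compounds shown here, methyl in place of hydrogen on a saturated chain carbon bound to a double-bonded chain carbon and a saturated chain carbon gives a 1.8-fold higher number from compound 2 to compound 3 (0.27 log units; within the scatter), the first direct reading at this position: turning but-1-en-1-yl into 3-methylbut-1-en-1-yl leaves the number within the scatter. The second single-place pair, 6-methoxypyridin-3-yl in place of 4-methoxyphenyl on a nitrogen on an aromatic ring, gives a 1.1-fold lower number from compound 1 to compound 3 (0.03 log units; within the scatter), so this exchange also stays within the scatter while 3-methylbut-1-en-1-yl is held constant. Neither change separates the compounds in this test, and no accompanying data offer an explanation for these numbers.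

Still open, on these data alone, is whether a longer chain or a dimethylamino group in place of 3-methylbut-1-en-1-yl would move the number beyond the scatter. Also open, as far as these compounds go, is whether an amine or a carboxylic acid in place of the methoxy group on 6-methoxypyridin-3-yl would separate a compound from this narrow set.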